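This account rests on a few compounds, and the source may have more. Where it says the series, first, only, none or still open, it means among the compounds named here.

Three members of the series have been tested in an ADME assay on HepG2 2.2.15 cells (Homo sapiens) for cytotoxicity, read by MTT assay, with stated times of 48 h and 9 days; a higher number here means that more compound is tolerated, a lower number that less compound is tolerated. Compound 1 `COc1ccc2c(=O)c(/C=C/C(=O)Nc3cccc(Cl)c3)coc2c1` gives 1100000 nM, compound 2 `COc1ccc2c(=O)c(/C=C/C(=O)Nc3ccc(C)cc3)coc2c1` gives 979000 nM, and compound 3 `COc1ccc2c(=O)c(/C=C/C(=O)NCc3ccccc3F)coc2c1` gives 146000 nM. Compound 2 stands second highest of the three: nearest is compound 1, with a 1.1-fold lower number from compound 1 to compound 2 (0.05 log units; within the scatter), and furthest is compound 3, with a 6.7-fold lower number from compound 2 to compound 3 (0.83 log units; beyond the scatter). Compound 4 `COc1ccc2c(=O)c(/C=C/C(=O)NCc3ccc(F)cc3F)coc2c1` carries 2,4-difluorobenzyl in place of 4-methylphenyl on an amide-type nitrogen. The step from compound 2 to compound 3 bears on this change directly, and the step of a 7.5-fold lower number from compound 1 to compound 3 (0.88 log units; beyond the scatter) points the same way. Compound 3, with its own benzyl group, gives 146000 nM. A drop of similar size is therefore expected for compound 4, a 6.5-fold lower number from compound 2 to compound 4 (0.81 log units; beyond the scatter). Compound 4 is estimated at 150000 nM, in a range from 60000 nM to 400000 nM.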

Compound 4, half-maximal cytotoxic concentration: 79300 nM
Beside the measured number, compound 4's estimate is 1.9-fold (0.28 log units) above it; the measured number falls inside the stated range.
By their numbers in this assay, from the lowest: compounds 4 and 3 (each within the scatter of the next); then compounds 2 and 1 (each within the scatter of the next).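

In this assay, fluoro in place of hydrogen on an aromatic carbon does not separate the two fluorinated benzyl amides: a 1.8-fold lower number from compound 3 to compound 4 (0.27 log units; within the scatter). With 2,4-difluorobenzyl on the amide-type nitrogen, the steps from the phenyl amides are large: a 12-fold lower number from compound 2 to compound 4 (1.09 log units; beyond the scatter), and a 14-fold lower number from compound 1 to compound 4 (1.14 log units; beyond the scatter). Among these four compounds, the main divide therefore lies between the fluorinated benzyl groups and the substituted phenyl groups.

No data at hand explain this divide. An unsubstituted benzyl group or a fluorophenyl group would show whether it follows the benzyl carbon or the fluoro substituents.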